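Shifting the ring nitrogen on the shared core

The source may report more compounds than this note shows. Statements on the series, on what has been measured and on what is new or still open speak of the compounds shown alone.

Compound 1, `CN(C)c1cccc(C(=O)N[C@H]2CCC[C@H](NC(=O)c3cccc(Cl)c3)C2)c1`, reaches only the assay limit of > 10000 nM in a functional assay on HEK293 cells for antagonist activity at metabotropic glutamate receptor 5 (Homo sapiens), read by FLIPR and calcium flux; on this read-out lower numbers stand for stronger inhibition and higher numbers for weaker inhibition.
Compound 2, `O=C(N[C@H]1CCC[C@H](NC(=O)C2CCCCC2)C1)c1cccc(Cl)c1`, gives 857 nM in this assay.
Compound 3, `O=C(N[C@H]1CCC[C@H](NC(=O)c2ccccn2)C1)c1cccc(Cl)c1`, reaches only the assay limit of > 10000 nM in this assay.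

Compound 3 therefore stands at the limit of the read-out rather than at a number, and it shares that position with compound 1 (the limit of > 10000 nM in this assay, at which 2 of the 3 values shown sit); only compound 2 carries a measured value. Compound 4, `O=C(N[C@H]1CCC[C@H](NC(=O)c2cccc(Cl)c2)C1)c1cccnc1`, differs from compound 3 by pyridin-3-yl in place of pyridin-2-yl on a carbonyl carbon. Going by the values given here, no measured step moves the nitrogen within the ring; the steps that bear on this position are an at least 11-fold higher number from compound 2 to compound 3 (1.06 log units; beyond the scatter) and an at least 11-fold lower number from compound 1 to compound 2 (1.06 log units; beyond the scatter), both large, while a step that the two limits leave unreadable from compound 1 to compound 3 cannot be read. Among the compounds with values here, both aromatic amides on this carbonyl sit at the limit, and the one numbered value belongs to the cyclohexyl amide of compound 2. Compound 4 is therefore expected to stay near the limit, giving a number no higher from compound 3 to compound 4 (the limit leaves the size open), with no step beyond the scatter expected. The estimate for compound 4 is 10000 nM, in the range 3000 nM to 30000 nM.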

Compound 4, half-maximal inhibitory concentration: 612 nM
Beside the measured number, compound 4's estimate is 16-fold (1.21 log units) above it, outside the stated range (below it).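

Swapping pyridin-2-yl for pyridin-3-yl on a carbonyl carbon, with the same atoms joined differently, turns a limit into a measured number in this assay (an at least 16-fold lower number from compound 3 to compound 4 (1.21 log units; beyond the scatter)), so the place of the ring nitrogen alone decides the outcome here. An aromatic ring on this carbonyl therefore does not hold the read-out at the limit by itself: the change from the 3-(dimethylamino)phenyl amide also gives a large step (an at least 16-fold lower number from compound 1 to compound 4 (1.21 log units; beyond the scatter)), while the pyridin-3-yl amide stands level with the cyclohexyl amide (a 1.4-fold lower number from compound 2 to compound 4 (0.15 log units; within the scatter)). Compound 1 and compound 3 remain at a limit of the assay, not at a number: the limit of > 10000 nM in this assay, at which 2 of the 4 values shown sit.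

As far as these compounds go, it remains open whether pyridin-4-yl on this carbonyl would also give a measured number. Also open, from the compounds shown here alone, is how a methoxy group or an amine on the pyridin-3-yl ring would shift it.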